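The compounds below may be only part of what the source reports. "The series", "measured", "known", "first", "only" and "open" are said of these compounds alone.

Working notes on the series.

Compound 1 `c1ccc(-c2ccccc2OCc2c[nH]cn2)cc1` sets the reference point: in an assay for binding affinity to Alpha-1D adrenergic receptor (Homo sapiens) (a higher number here means a weaker inhibitor, a lower number a stronger inhibitor), compound 1 gives 933 nM. Compound 2 `CCN(CC)C(=O)c1ccccc1OCC1=NCCN1` is a different case, since in this assay compound 2 is recorded only as a limit, < 30200 nM, and not as a number. The evidence that fixes its standing is just (the limit of < 30200 nM in this assay, at which 1 of the 2 values shown sits), so compound 2 cannot be ranked against compound 1 beyond that.

Compound 3 `CCN(CC)C(=O)c1ccccc1OCc1c[nH]cn1` has not yet been measured in this assay. It is reached from compound 2 through one change: a group of 5 heavy atoms (3 carbon, 2 nitrogen; one five-membered aromatic ring with 2 hetero atoms) in place of a group of 5 heavy atoms (3 carbon, 2 nitrogen; one five-membered non-aromatic ring with 2 hetero atoms), on a saturated chain carbon bound to an oxygen on an aromatic ring. Among the measured compounds shown here, no measured pair in the set spans this change, so its size is open. Compound 1 carries the same entering group on another core and gives 933 nM, which is the only anchor for the entering group. Given that anchor, compound 3 is expected to give a real number rather than a limit, and the expected step is a step that the limit leaves unreadable from compound 2 to compound 3. The estimate for compound 3 in this assay is 3000 nM, with a range from 600 nM to 15000 nM.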

Compound 3, half-maximal inhibitory concentration: < 30200 nM
Compound 3 ended at the assay's limit (the forecaster's own chance of this, stated with the estimate: 15%); the middle value does not contradict the limit.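

Compound 2 and compound 3 are each recorded in this assay only as a limit, so no step can be read between them: the limit of < 30200 nM in this assay, at which 2 of the 3 values shown sit.

The compounds shown leave open how large the effect of 1H-imidazol-4-yl in place of the five-membered non-aromatic ring is on this core.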